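Changing the Amide Partner on a Shared Core

This account rests on a few compounds, and the source may have more. Where it says the series, first, only, none or still open, it means among the compounds named here.

Three compounds have been measured in a functional assay on A549 cells (Homo sapiens) for inhibition, read by sulforhodamine B assay, with a stated time of 72 h; a higher number here means a weaker inhibitor, a lower number a stronger inhibitor:

compound 1 `Nc1sc(-c2ccc(Cl)cc2)c(-c2ccc(Cl)cc2)c1C(=O)NC1CCCCC1` gives 2410 nM
compound 2 `Nc1sc(-c2ccc(Cl)cc2)c(-c2ccc(Cl)cc2)c1C(=O)NC1CC1` gives 1950 nM
compound 3 `Nc1sc(-c2ccc(Cl)cc2)c(-c2ccc(Cl)cc2)c1C(=O)N1CCCCC1=O` gives 1820 nM

Compound 3 holds the lowest of the three numbers, yet its gaps to the other two are both within the scatter: a 1.3-fold lower number from compound 1 to compound 3 (0.12 log units; within the scatter) and a 1.1-fold lower number from compound 2 to compound 3 (0.03 log units; within the scatter). The three therefore read as one level, not an order.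

Compound 4 `CCCCNC(=O)c1c(N)sc(-c2ccc(Cl)cc2)c1-c1ccc(Cl)cc1` keeps the shared core and again alters only the group on the carbonyl carbon: butylamino in place of 2-oxopiperidin-1-yl on a carbonyl carbon. Every measured step touches the same spot. Exchanging cyclohexylamino for cyclopropylamino gave a 1.2-fold lower number from compound 1 to compound 2 (0.09 log units; within the scatter), and exchanging either for 2-oxopiperidin-1-yl gave steps of similar size, all within the scatter. Nothing here suggests that a butylamino group would behave differently, so the expected step of a 1.1-fold higher number from compound 3 to compound 4 (0.04 log units; within the scatter) is none beyond the scatter, in either direction. Compound 4 is estimated at 2000 nM in this assay, with a range from 1000 nM to 4500 nM.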

Compound 4, half-maximal inhibitory concentration: 8170 nM
Compound 4: middle estimate off by 4.1-fold (0.61 log units), on the low side; the whole stated range lies below it.
By their numbers in this assay, from the lowest: compounds 3, 2 and 1 (each within the scatter of the next); then compound 4.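

The group on this carbonyl carbon does matter after all, since butylamino sets compound 4 apart from all three earlier compounds (a 4.5-fold higher number from compound 3 to compound 4 (0.65 log units; beyond the scatter); a 4.2-fold higher number from compound 2 to compound 4 (0.62 log units; beyond the scatter); a 3.4-fold higher number from compound 1 to compound 4 (0.53 log units; beyond the scatter)). Among these four compounds, the only group without a ring gives the weakest inhibitor, while the three ring-bearing groups remain on one level. The amide hydrogen does not track this split, as compounds 1, 2 and 4 all keep it, yet compounds 1 and 2 stay level with compound 3, which lacks it, and no measurement on hand explains the drop.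

Whether this applies to open chains generally or to butyl alone remains unresolved. An ethyl or a hexyl chain on the same nitrogen would help separate chain length from the absence of a ring.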